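From diethylamino to 4-methylpiperazin-1-yl on compound 2

The source may hold more compounds than are shown below. What is called first, only, known or untested is meant among the compounds shown, and "the series" means these compounds.

Measured so far in a functional assay on A549 cells (Homo sapiens) for antiproliferative activity, read by MTT assay, with a stated time of 48 h (a higher number here means a weaker inhibitor, a lower number a stronger inhibitor), for each compound
Compound 1 `CCn1c(N)c(-c2nc3ccccc3[nH]2)c2nc(C#N)c(C#N)nc21` gives > 50000 nM (a limit)
Compound 2 `CCN(CC)CCn1c(N)c(-c2nc3ccccc3[nH]2)c2nc(C#N)c(C#N)nc21` gives > 50000 nM (a limit)

Compound 2 stands at > 50000 nM as a limit and not a number. The standing of both compounds is summed up by the limit of > 50000 nM in this assay, at which 2 of the 2 values shown sit, and nothing finer.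

Compound 3 `CN1CCN(CCn2c(N)c(-c3nc4ccccc4[nH]3)c3nc(C#N)c(C#N)nc32)CC1` keeps the shared core and carries 4-methylpiperazin-1-yl in place of diethylamino, on a saturated chain carbon, two bonds along the chain from an aromatic nitrogen (4-methylpiperazin-1-yl in place of diethylamino on a saturated chain carbon, two bonds along the chain from an aromatic nitrogen).

Going by the values given here, the one measured step that bears on this change is a step that the two limits leave unreadable from compound 1 to compound 2 and it offers no size to carry over. No step beyond the scatter is therefore expected in this assay and no direction is favoured. The expected step is a number no higher from compound 2 to compound 3 (the limit leaves the size open) and it is only an estimate. Compound 3 is expected at 50000 nM with a range of 20000 nM to 100000 nM. A limit may well be the outcome again.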

Compound 3, half-maximal inhibitory concentration: 40500 nM
Estimate against measurement, compound 3: 1.2-fold (0.09 log units) above; the range from low to high includes it.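

In this assay, going by these compounds alone, compound 3, with 4-methylpiperazin-1-yl, gives 40500 nM, the only value at this position that is a number and not a limit. Set against the two limits, this change reads as an at least 1.2-fold lower number from compound 2 to compound 3 (0.09 log units; that floor lies within the scatter), and as an at least 1.2-fold lower number from compound 1 to compound 3 (0.09 log units; that floor lies within the scatter). The step from compound 1 to compound 2 cannot be read, and the other two steps give only a floor, not a full size: the limit of > 50000 nM in this assay, at which 2 of the 3 values shown sit.

On these data alone, it remains open whether morpholin-4-yl or piperidin-1-yl in the same place would also give a number and not a limit. As far as these compounds go, it is equally open what a longer chain carrying 4-methylpiperazin-1-yl would give, or whether the second ring nitrogen of that group plays any part.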